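One group exchanged in a small cytotoxic series

The source may report more compounds than this note shows. Statements on the series, on what has been measured and on what is new or still open speak of the compounds shown alone.

Compound 1 `CCn1cc(-c2nc3ccccc3[nH]2)c(=O)c2cc(F)c(N3CCNCC3)nc21`: 4800 nM
Compound 2 `CCn1cc(-c2nc3ccccc3[nH]2)c(=O)c2cc(F)c(N3CCNC(C)C3)c(F)c21`: 11600 nM
Compound 3 `CCn1cc(-c2nc3ccccc3o2)c(=O)c2cc(F)c(Cl)cc21`: 78400 nM

In a functional assay on A2780 cells (Homo sapiens) for cytotoxicity, read by MTT assay, with a stated time of 48 h (on this read-out higher numbers stand for weaker inhibition and lower numbers for stronger inhibition), compound 2 gives 11600 nM, the middle of the three numbers. It lies above compound 1 and below compound 3, and both gaps exceed the usual scatter. Compound 4 `CCn1cc(-c2nc3ccccc3o2)c(=O)c2cc(F)c(N3CCNC(C)C3)c(F)c21` is compound 2 with a single exchange: 1,3-benzoxazol-2-yl in place of 1H-benzimidazol-2-yl on an aromatic carbon. Going by the values given here, no measured pair shows this exchange alone. Compound 3 carries the entering group and gives 78400 nM, yet it also differs from compound 2 elsewhere, so it is only a loose guide. A modest rise in the number, meaning weaker inhibition, is expected for the step of a 2.2-fold higher number from compound 2 to compound 4 (0.35 log units; beyond the scatter). For compound 4 the estimated value is 26000 nM, with an expected range of 9000 nM to 70000 nM.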

Compound 4, half-maximal inhibitory concentration: 83500 nM
Beside the measured number, compound 4's estimate is 3.2-fold (0.51 log units) below it; the whole stated range lies below it.
By their numbers in this assay, from the lowest: compound 1; then compound 2; then compounds 3 and 4 (each within the scatter of the next).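

In this assay, exchanging 1H-benzimidazol-2-yl for 1,3-benzoxazol-2-yl on this aromatic carbon gives a 7.2-fold higher number from compound 2 to compound 4 (0.86 log units; beyond the scatter), and no other part of the structure changes. This shows that the group at this position matters on its own for inhibition in these cells, with the benzimidazole version the stronger of the two. Nothing given here explains the difference. As far as these compounds go, it remains open whether the same exchange would weaken inhibition on the core of compound 1, and how a carboxylic acid or an amine at this position would compare.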